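This account rests on a few compounds, and the source may have more. Where it says the series, first, only, none or still open, it means among the compounds named here.

Compound 1 `CCCn1c(N2CCN(C)CC2)nc2ccccc21`: 380 nM
Compound 2 `CCOCCn1c(N2CCN(c3ccccc3)CC2)nc2ccccc21`: > 10000 nM

For the measured compounds named here, in a functional assay on ileum for inhibition of histamine H1 receptor (Cavia porcellus) (a lower number here means a stronger inhibitor, a higher number a weaker inhibitor), compound 1 gives 380 nM, the only plain number among the two values. Compound 2 gives > 10000 nM in this assay, which is a limit rather than a number. This reflects (the limit of > 10000 nM in this assay, at which 1 of the 2 values shown sits). Compound 3 `CCSCCn1c(N2CCN(C)CC2)nc2ccccc21` differs from compound 1 in one place: ethylsulfanyl in place of methyl on a saturated chain carbon, two bonds along the chain from an aromatic nitrogen. Going by the values given here, no measured step of this kind is available, so the change is expected to be small in this assay, at most a modest shift toward weaker inhibition and possibly nothing beyond the scatter. Compound 3 is therefore estimated at 600 nM, within 150 nM to 3000 nM, an expected step of a 1.6-fold higher number from compound 1 to compound 3 (0.20 log units; within the scatter).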

Compound 3, half-maximal inhibitory concentration: 19 nM
The estimate for compound 3 lay 32-fold (1.50 log units) above the measured number; measured number below the stated range.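

In this assay, ethylsulfanyl in place of methyl on a saturated chain carbon, two bonds along the chain from an aromatic nitrogen, brings a 20-fold lower number from compound 1 to compound 3 (1.30 log units; beyond the scatter), so this chain position responds strongly to what it carries. Compound 2 differs from compound 1 and compound 3 in more than one place and its value is a limit, so it offers no comparison here. Nothing measured here accounts for the size of this step. As far as these compounds go, what a pentyl chain or a 2-ethoxyethyl group would give on the core of compound 1 stays open, so the effect of the sulfur cannot be separated from that of the longer chain.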